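A few compounds are considered here, and "the series" means these few. Any claim that something is new, unique, unknown or untested is made for them only; others in the source may bear on it.

Measured so far in a toxicity assay on MT4 cells (Homo sapiens) for cytotoxicity, read by MTT assay; on this read-out lower numbers stand for higher toxicity in this test and higher numbers for lower toxicity in this test:
compound 1 `Cc1cc(-c2cccc(Cl)c2)cc(C)c1Oc1cc(N)nc(Nc2ccc(C#N)cc2)n1`: 22300 nM
compound 2 `Cc1ccccc1-c1cc(C)c(Oc2cc(N)nc(Nc3ccc(C#N)cc3)n2)c(C)c1`: 25600 nM
compound 3 `Cc1cc(-c2ccccc2C#N)cc(C)c1Oc1cc(N)nc(Nc2ccc(C#N)cc2)n1`: 25400 nM
Not yet measured: compound 4 `Cc1cc(-c2cccc(C#N)c2)cc(C)c1Oc1cc(N)nc(Nc2ccc(C#N)cc2)n1`

In this assay compound 3 gives 25400 nM and lies within the scatter of both other values, so the three numbers carry no meaningful order.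

Compound 4 differs from compound 3 in one group only: 3-cyanophenyl in place of 2-cyanophenyl on an aromatic carbon and the rest of the structure is shared.

Among the measured compounds shown here, three measured steps bear on this change. The first is a 1.1-fold higher number from compound 1 to compound 3 (0.06 log units; within the scatter) and the second is a 1.1-fold higher number from compound 1 to compound 2 (0.06 log units; within the scatter) while the third is a 1.0-fold lower number from compound 2 to compound 3 (0.00 log units; within the scatter) and all three stay within the scatter. For the measured compounds named here, compound 1 carries 3-chlorophenyl and compound 3 carries 2-cyanophenyl, so the closest guide is a 1.1-fold higher number from compound 1 to compound 3 (0.06 log units; within the scatter) but no measured pair isolates the exact swap, and the evidence is indirect.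

No step beyond the scatter is expected in this assay for this change. The estimated result is a 1.1-fold lower number from compound 3 to compound 4 (0.02 log units; within the scatter) and it is expected to stay within the scatter.

Compound 4 is estimated at 24000 nM within an expected range of 12000 nM to 45000 nM on this read-out.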

Compound 4, half-maximal cytotoxic concentration: 20200 nM
Compound 4: middle estimate off by 1.2-fold (0.07 log units), on the high side, within the range that was stated.
By their numbers in this assay, from the lowest: compounds 4, 1, 3 and 2 (each within the scatter of the next).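

In this assay, among the compounds shown here, 3-cyanophenyl in place of 2-cyanophenyl is the first pair that differs only in where the nitrile stands on the phenyl group, and it gives a 1.3-fold lower number from compound 3 to compound 4 (0.10 log units; within the scatter) with no separation between the two compounds in this test. The other two pairs read the same way, with a 1.3-fold lower number from compound 2 to compound 4 (0.10 log units; within the scatter) for the exchange of 2-methylphenyl and a 1.1-fold lower number from compound 1 to compound 4 (0.04 log units; within the scatter) for cyano in place of chloro, so the four phenyl groups at this place, including two placements of the nitrile and a chloro at the same place as a nitrile, cannot be ranked on this read-out. Nothing available accounts for this flat result.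

As far as these compounds go, the four compounds all carry a substituted phenyl group at this place, so it remains open whether the same flat read-out would hold with 4-cyanophenyl or with a group of a different kind, such as a morpholine, a carboxylic acid or a longer alkyl chain. From the compounds shown here alone, it also remains open whether any change at this place can move the number beyond the scatter in either direction.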